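Working notes: from 2-acetylethenyl to 2-cyanoethenyl

This account rests on a few compounds, and the source may have more. Where it says the series, first, only, none or still open, it means among the compounds named here.

- compound 1 `Cc1cc(Br)cc(C)c1Oc1ccc([N+](=O)[O-])c(Nc2ccc(C#N)cc2)n1`: > 45600 nM (a limit)
- compound 2 `Cc1cc(/C=C/C#N)cc(C)c1Oc1ccc([N+](=O)[O-])c(Nc2ccc(C#N)cc2)c1`: > 48700 nM (a limit)
- compound 3 `CC(=O)/C=C/c1cc(C)c(Oc2cc(Nc3ccc(C#N)cc3)c([N+](=O)[O-])cc2[N+](=O)[O-])c(C)c1`: 24400 nM

Among the measured compounds shown here, in an ADME assay on TZM cells (Homo sapiens) for cytotoxicity, read by XTT assay, with a stated time of 4 days (on this read-out lower numbers stand for higher toxicity in this test and higher numbers for lower toxicity in this test), compound 3 gives 24400 nM, the only actual number so far. The other two results are limits.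

Compound 4 `Cc1cc(/C=C/C#N)cc(C)c1Oc1cc(Nc2ccc(C#N)cc2)c([N+](=O)[O-])cc1[N+](=O)[O-]` differs from compound 3 by cyano in place of acetyl on a double-bonded chain carbon bound to a double-bonded chain carbon.

Compound 2 also carries 2-cyanoethenyl, and its > 48700 nM is a limit.

For the measured compounds named here, no measured pair isolates this change, so no step beyond the scatter is expected in this assay. The estimated 1.1-fold higher number from compound 3 to compound 4 (0.06 log units; within the scatter) is small. For compound 4 the estimate is 28000 nM, with an expected range of 10000 nM to 65000 nM.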

Compound 4, half-maximal cytotoxic concentration: > 43900 nM
Compound 4 gave a limit, no number; the forecaster's own chance of this, stated with the estimate: 35%; middle value at least 1.5-fold (0.19 log units) from the limit.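

In this assay, the swap of 2-acetylethenyl for 2-cyanoethenyl now has its first matched pair, with an at least 1.7-fold higher number from compound 3 to compound 4 (0.25 log units; that floor lies within the scatter). Compound 4 gives > 43900 nM, which is a limit, so only a floor for this step can be read. The step from nitro in place of hydrogen on an aromatic carbon, linking compound 2 and compound 4, cannot be read, since both values are limits.

From the compounds shown here alone, whether cyano in place of acetyl shifts the number beyond the scatter stays open. Also open, going by these compounds, is what an amine or a carboxylic acid would give at this place on the chain.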